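This account rests on a few compounds, and the source may have more. Where it says the series, first, only, none or still open, it means among the compounds named here.

Three compounds have been measured in a functional assay on HepG2 cells (Homo sapiens) for inhibition, read by MTT assay, with a stated time of 24 h; a lower number here means a stronger inhibitor, a higher number a weaker inhibitor:

Compound 1 `CC1(C)[C@H]2CC[C@]1(C)N(Cc1cn(-c3ccccc3)nn1)C(=O)C2`: 90 nM
Compound 2 `CC1(C)[C@H]2CC[C@]1(C)N(Cc1cn(-c3ccccc3Cl)nn1)C(=O)C2`: 60 nM
Compound 3 `CC1(C)[C@H]2CC[C@]1(C)N(Cc1cn(-c3ccc(C#N)cc3)nn1)C(=O)C2`: 50 nM

Compound 3 has the lowest of the three numbers, yet the two steps leading to it are a 1.2-fold lower number from compound 2 to compound 3 (0.08 log units; within the scatter) and a 1.8-fold lower number from compound 1 to compound 3 (0.26 log units; within the scatter), so the three cannot be ranked. Compound 4 `COc1cccc(-n2cc(CN3C(=O)C[C@@H]4CC[C@@]3(C)C4(C)C)nn2)c1` differs from compound 3 in one place: 3-methoxyphenyl in place of 4-cyanophenyl on an aromatic nitrogen. The two steps that bear on this are the swap of one phenyl substituent for another, from compound 2 to compound 3, and cyano in place of hydrogen, from compound 1 to compound 3; neither left the scatter. A further change of the group on the same ring nitrogen is therefore expected to produce no step beyond the scatter in this assay, an expected step of a 1.4-fold higher number from compound 3 to compound 4 (0.15 log units; within the scatter). Compound 4 is estimated at 70 nM, within a range of 30 nM to 170 nM.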

Compound 4, half-maximal inhibitory concentration: 70 nM
Estimate against measurement, compound 4: no gap at the digits printed; the range from low to high includes it.
By their numbers in this assay, from the lowest: compounds 3, 2, 4 and 1 (each within the scatter of the next).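

Replacing 4-cyanophenyl with 3-methoxyphenyl on the ring nitrogen gives a step that stays within the scatter in this assay (a 1.4-fold higher number from compound 3 to compound 4 (0.15 log units; within the scatter)). So do replacing 2-chlorophenyl with 3-methoxyphenyl (a 1.2-fold higher number from compound 2 to compound 4 (0.07 log units; within the scatter)) and placing methoxy on the plain phenyl ring (a 1.3-fold lower number from compound 1 to compound 4 (0.11 log units; within the scatter)). A methoxy group therefore joins chloro and cyano as a third substituent on this phenyl ring, and the four compounds cannot be ranked.

On these data alone, it remains open whether an amine or a carboxylic acid on this phenyl ring, or a longer alkyl chain in place of the ring, would move the number beyond the scatter. Nothing shown here explains why these four numbers lie so close together.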